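Swapping a para substituent on a thiosemicarbazone aryl ring

The source may report more compounds than this note shows. Statements on the series, on what has been measured and on what is new or still open speak of the compounds shown alone.

Compound 1 `CC1=CC[C@@H]([C@@](C)(O)CCCC(C)(C)NC=S)CC1` is the simplest member of this small set; in a functional assay on PCO3 cells (Homo sapiens) for cytotoxicity, read by sulforhodamine B assay (a higher number here means a weaker inhibitor of growth, a lower number a stronger inhibitor of growth), compound 1 gives 11000 nM. Compound 2 `CC1=CC[C@@H]([C@@](C)(O)CCCC(C)(C)NC(=S)N/N=C\c2ccc(O)cc2)CC1` carries a hydrazone-linked phenol on the thiourea sulfur side, and compound 2 gives 6230 nM. Compound 3 `CC1=CC[C@@H]([C@@](C)(O)CCCC(C)(C)NC(=S)N/N=C\c2ccc(N(C)C)cc2)CC1` replaces that phenol hydroxy with a dimethylamino group, and compound 3 gives 13700 nM, the highest of the three numbers: it sits within the scatter of compound 1 but a 2.2-fold higher number from compound 2 to compound 3 (0.34 log units; beyond the scatter), a modest step beyond the scatter.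

Compound 4 `CC1=CC[C@@H]([C@@](C)(O)CCCC(C)(C)NC(=S)N/N=C\c2ccc(Cl)cc2)CC1` differs from compound 3 in one place: chloro in place of dimethylamino on an aromatic carbon. Among the measured compounds shown here, only one measured step touches this aromatic carbon, the exchange of hydroxy for dimethylamino, which moved the number modestly upward from compound 2 to compound 3. For the measured compounds named here, no measured compound carries a chloro at this position, so the effect of this substituent is untested here. Taking the two values on that carbon as the available range, compound 4 is expected to land between them, giving a 1.6-fold lower number from compound 3 to compound 4 (0.21 log units; within the scatter) as an estimate, with the chance that it stays within the scatter of compound 3. The estimate for compound 4 in this assay is 8500 nM, in a range from 3500 nM to 20000 nM.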

Compound 4, concentration for 50% growth inhibition: 7580 nM
Compound 4: middle estimate off by 1.1-fold (0.05 log units), on the high side, within the range that was stated.
By their numbers in this assay, from the lowest: compounds 2, 4, 1 and 3 (each within the scatter of the next, the first and the last beyond it).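

In this assay the chloro group fills in the middle of the picture at this aromatic carbon: changing hydroxy to chloro gives a 1.2-fold higher number from compound 2 to compound 4 (0.09 log units; within the scatter) and changing dimethylamino to chloro gives a 1.8-fold lower number from compound 3 to compound 4 (0.26 log units; within the scatter) so compound 4 cannot be told apart from either compound, even though those two are separated by a 2.2-fold higher number from compound 2 to compound 3 (0.34 log units; beyond the scatter) and differ beyond the scatter. The earlier step alone left open whether hydroxy was needed to keep the lower number seen with compound 2, and the chloro group, a single chlorine atom with no hydrogen-bond donor, now shows that it is not needed in this small set. Nothing measured here accounts for how these three groups compare at this carbon.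

From the compounds shown here alone, with only hydroxy, dimethylamino and chloro at this carbon, and all three results lying close together, it remains open whether a carboxylic acid, a methoxy group, a nitrile or an unsubstituted phenyl ring would stay in the same range or leave it. Also open, going by these compounds, is whether chloro would give a similar number on a different carbon of the same ring.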